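The compounds below may be only part of what the source reports. "The series", "measured", "known", "first", "only" and "open" are said of these compounds alone.

Three compounds share one core and differ only in the group carried on the amide-type nitrogen. Compound 1 `COc1ccc(NC(=O)[C@H]2CN(C)C[C@@H]2c2ccc(/C=C/C(=O)Nc3ccccc3N)cc2)cc1` carries a 4-methoxyphenyl there, and in an in vitro ADME assay on microsomes from liver (Mus musculus) for pharmacokinetics, read by LC-MS, with a stated time of 10 min, tested at 1 uM (on this read-out higher numbers stand for fast clearance and lower numbers for slow clearance), compound 1 gives 54 mL/min/kg. Compound 2 `CN1C[C@H](C(=O)Nc2ccc(C3CC3)cc2)[C@@H](c2ccc(/C=C/C(=O)Nc3ccccc3N)cc2)C1` carries a 4-cyclopropylphenyl, and in this assay compound 2 gives 60 mL/min/kg. Compound 3 `Cc1cc(NC(=O)[C@H]2CN(C)C[C@@H]2c2ccc(/C=C/C(=O)Nc3ccccc3N)cc2)ccc1F` carries a 4-fluoro-3-methylphenyl, and in this assay compound 3 gives 62 mL/min/kg. These numbers sit close together, with a 1.1-fold higher number from compound 1 to compound 3 (0.06 log units; within the scatter) and a 1.0-fold higher number from compound 2 to compound 3 (0.01 log units; within the scatter), so compound 3 cannot be set apart from the other two.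

Compound 4 `CC(C)NC(=O)[C@H]1CN(C)C[C@@H]1c1ccc(/C=C/C(=O)Nc2ccccc2N)cc1` has not yet been measured. The change from compound 3 to compound 4 is isopropyl in place of 4-fluoro-3-methylphenyl on an amide-type nitrogen. Going by the values given here, the steps that touch this place, a 1.1-fold higher number from compound 1 to compound 2 (0.05 log units; within the scatter), a 1.1-fold higher number from compound 1 to compound 3 (0.06 log units; within the scatter) and a 1.0-fold higher number from compound 2 to compound 3 (0.01 log units; within the scatter), each exchange one substituted phenyl for another and all stay within the scatter; none brings in an isopropyl, so there is no direct precedent. The expected step is therefore a 1.1-fold lower number from compound 3 to compound 4 (0.05 log units; within the scatter), nothing beyond the scatter. Compound 4 is estimated to give 55 mL/min/kg, with a range from 25 mL/min/kg to 110 mL/min/kg.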

Compound 4, clearance: 12 mL/min/kg
Compound 4: the middle estimate sits 4.6-fold (0.66 log units) above what was measured; the whole stated range lies above it.
By their numbers in this assay, from the lowest: compound 4; then compounds 1, 2 and 3 (each within the scatter of the next).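

The three substituted phenyl groups on the amide-type nitrogen could not be told apart, so this position might have seemed to make little difference in this assay. Isopropyl shows that it can matter: it gives a 5.2-fold lower number from compound 3 to compound 4 (0.71 log units; beyond the scatter) and a 5.0-fold lower number from compound 2 to compound 4 (0.70 log units; beyond the scatter) as well as a 4.5-fold lower number from compound 1 to compound 4 (0.65 log units; beyond the scatter) in the same place, so here the clear divide lies between these phenyl groups and isopropyl. Nothing measured here explains this difference.

Isopropyl differs from these phenyl groups both in having no ring and in having fewer heavy atoms, so the compounds shown cannot separate those two changes. A cyclohexyl ring would keep a ring without the aromatic character, while an ethyl or a longer alkyl chain would show how the number follows chain size.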